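This account rests on a few compounds, and the source may have more. Where it says the series, first, only, none or still open, it means among the compounds named here.

Compound 1 `COc1ccc(C2N=C(SCc3ccccc3)NC(C)=C2C(=O)Nc2ccc(Br)cc2)cc1` gives 13.3% in a functional assay on the whole organism (artery, strain albino) with Rattus norvegicus as the target, with a stated time of 240 min, at a dose of 10 mg/kg by the oral route; a higher number here means more inhibition at the dose given (going by the name of the read-out), a lower number less inhibition.
Compound 2 `CC1=C(C(=O)Nc2ccc([N+](=O)[O-])cc2)C(c2ccc(Br)cc2)N=C(SCc2ccccc2)N1` gives 27.7% in this assay.
Compound 3 `CC1=C(C(=O)Nc2ccc([N+](=O)[O-])cc2)C(c2cccc([N+](=O)[O-])c2)N=C(SCc2ccccc2)N1` gives 21% in this assay.

Compound 3 stands second highest of the three numbers in this assay. Its nearest neighbour is compound 2, and the step of a number 6.7 percentage points lower from compound 2 to compound 3 (within the scatter) lies within the scatter. Compound 1 is furthest away, yet that gap too is within the scatter, so no order among the three can be claimed.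

Compound 4 `CC1=C(C(=O)Nc2ccc([N+](=O)[O-])cc2)C(c2cccc([N+](=O)[O-])c2)N=C(SCc2cccc(Cl)c2)N1` has not been measured. It differs from compound 3 by chloro in place of hydrogen on an aromatic carbon, so that the benzylsulfanyl group of compound 3 becomes a (3-chlorobenzyl)sulfanyl group. Among the compounds with values here, no measured step touches this part of the core: the only step, from compound 2 to compound 3, alters the group on the saturated ring carbon and was within the scatter. There is therefore no basis for expecting a step beyond the scatter in this assay.

Compound 4 is expected to give 21% in this assay, with a range from 8% to 35%, which means an expected step of no change at the digits printed from compound 3 to compound 4 (within the scatter).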

Compound 4, a percentage reported as inhibition, in the whole organism at one dose (the size of the read-out at that dose, not a potency): 17.9%
The estimate for compound 4 lay 3.1 percentage points above the measured number; the range from low to high includes it.
By their numbers in this assay, from the lowest: compounds 1, 4, 3 and 2 (each within the scatter of the next, the first and the last beyond it).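

Within the data shown here, the (3-chlorobenzyl)sulfanyl group of compound 4 gives the first reading on this part of the molecule, which no earlier step had touched. In this assay, among these compounds, the result is a number 3.1 percentage points lower from compound 3 to compound 4 (within the scatter) and so chloro in place of hydrogen on this aromatic carbon, meta to a large group, brings no step that can be told from the scatter. Nothing measured here bears on why this is so.

A single chloro on the benzyl group cannot show whether this part of the molecule is insensitive to change in general. As far as these compounds go, it remains open whether another group there, such as an amine or a carboxylic acid, or a longer alkyl chain in place of the benzyl group, would give a step beyond the scatter.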